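From pyridin-3-yl to 2-chloropyridin-3-yl on a shared core

The source may hold more compounds than are shown below. What is called first, only, known or untested is meant among the compounds shown, and "the series" means these compounds.

In a functional assay on U-251 cells (Homo sapiens) for antiproliferative activity, read by MTT assay, with a stated time of 72 h (on this read-out lower numbers stand for stronger inhibition and higher numbers for weaker inhibition), compound 1 `O=C(Nc1ccc(Cl)c(-c2nnc3c(Cl)cccn23)c1)c1cccnc1` gives > 100000 nM as a limit of the assay, not a number. Compound 1 thus stands at the limit of > 100000 nM in this assay, at which 1 of the 2 values shown sits, and has no firm starting value. Compound 2 `O=C(Nc1ccc(Cl)c(-c2nnc3c(Cl)cccn23)c1)c1cccc(Cl)c1` gives 43100 nM in this assay with 3-chlorophenyl in place of pyridin-3-yl on a carbonyl carbon. Among the compounds with values here, the one measured step bearing on the next change is an at least 2.3-fold lower number from compound 1 to compound 2 (0.36 log units; beyond the scatter) and it also replaces the ring itself. Compound 3 `O=C(Nc1ccc(Cl)c(-c2nnc3c(Cl)cccn23)c1)c1cccnc1Cl` keeps the ring nitrogen and differs from compound 1 as follows: chloro in place of hydrogen on an aromatic carbon and pyridin-3-yl thereby becomes 2-chloropyridin-3-yl. Going by compound 2 and its step, a modest move toward lower numbers is expected in this assay and the result may still stay at the limit. The expected change is an at least 1.6-fold lower number from compound 1 to compound 3 (0.22 log units; that floor lies within the scatter) on this estimate. Compound 3 is estimated at 60000 nM with an expected range of 25000 nM to 100000 nM in this assay overall.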

Compound 3, half-maximal inhibitory concentration: > 100000 nM
Compound 3 ended at the assay's limit (the forecaster's own chance of this, stated with the estimate: 40%); middle value at least 1.6-fold (0.22 log units) from the limit.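

Compound 3 keeps the ring nitrogen and carries chloro on the aromatic carbon next to it, yet it gives only a limit and no number: the limit of > 100000 nM in this assay, at which 2 of the 3 values shown sit. The step from compound 1 to compound 3 cannot be read, so the data do not show whether this chloro changes activity at all. The comparison with the 3-chlorophenyl amide can be read as an at least 2.3-fold higher number from compound 2 to compound 3 (0.36 log units; beyond the scatter), which shows that a chloro on the ring does not by itself carry the lower number of compound 2, although this step changes the ring as well as the place of the chloro.

On these data alone, how far compound 1 and compound 3 lie past the limit remains open. Also open, as far as these compounds go, is whether an amine or a methyl group on the same aromatic carbon would give a measurable number.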